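Swapping the pyrazole for a phenoxy group

The compounds below may be only part of what the source reports. "The series", "measured", "known", "first", "only" and "open" are said of these compounds alone.

Of the compounds shown here, three sharing one core have been tested in a functional assay for agonist activity at growth hormone secretagogue receptor type 1 (Homo sapiens), read by FLIPR; on this read-out lower numbers stand for an effect already at smaller amounts and higher numbers for an effect only at larger amounts of compound. Compound 1 `COc1ccc(N2C[C@@H](C)N[C@@H](C)C2)cc1NS(=O)(=O)c1ccc(-c2cncnc2)cc1` gives 316 nM. Compound 2 `COc1ccc(N2C[C@@H](C)N[C@@H](C)C2)cc1NS(=O)(=O)c1ccc(N2CCCC2=O)cc1` gives 39.8 nM. Compound 3 `COc1ccc(N2C[C@@H](C)N[C@@H](C)C2)cc1NS(=O)(=O)c1ccc(-n2cccn2)cc1` gives 15.9 nM, the lowest of the three numbers; it is separated from compound 2 by a 2.5-fold lower number from compound 2 to compound 3 (0.40 log units; beyond the scatter) and from compound 1 by a 20-fold lower number from compound 1 to compound 3 (1.30 log units; beyond the scatter), both steps beyond the scatter. Compound 4 `COc1ccc(N2C[C@@H](C)N[C@@H](C)C2)cc1NS(=O)(=O)c1ccc(Oc2ccccc2)cc1` is the next step: phenoxy in place of 1H-pyrazol-1-yl on an aromatic carbon.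

Among the measured compounds shown here, the steps that bear on it are those that replace another ring at the same carbon with the pyrazolyl group, namely a 20-fold lower number from compound 1 to compound 3 (1.30 log units; beyond the scatter) and a 2.5-fold lower number from compound 2 to compound 3 (0.40 log units; beyond the scatter); in both, the pyrazolyl group gave the lowest number. For the measured compounds named here, removing it for a phenoxy group, which appears in none of the measured compounds, is therefore expected to raise the number by a modest to large amount rather than lower it, with wide uncertainty. For compound 4 the expected step is a 4.0-fold higher number from compound 3 to compound 4 (0.60 log units; beyond the scatter). Compound 4 is thus estimated at 63 nM, within a range of 16 nM to 250 nM.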

Compound 4, half-maximal effective concentration: 63.1 nM
For compound 4 the middle estimate is 1.0-fold (0.00 log units) below the measured one; measured number inside the range.
By their numbers in this assay, from the lowest: compound 3; then compounds 2 and 4 (each within the scatter of the next); then compound 1.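

In this assay, phenoxy brings an aromatic ring of carbon only to this carbon, para to a large group, and it gives up part of what the pyrazole achieved (a 4.0-fold higher number from compound 3 to compound 4 (0.60 log units; beyond the scatter)), leaving 1H-pyrazol-1-yl with the lowest number of the four. Phenoxy still improves clearly on pyrimidin-5-yl (a 5.0-fold lower number from compound 1 to compound 4 (0.70 log units; beyond the scatter)) and cannot be told apart from 2-oxopyrrolidin-1-yl (a 1.6-fold higher number from compound 2 to compound 4 (0.20 log units; within the scatter)). Nitrogen in this group is therefore not required for a number in this range, and having it is no guarantee either, since the two nitrogen-bearing aromatic rings, in compound 3 and compound 1, sit at opposite ends of the series.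

Still open, on these data alone, is how a directly attached phenyl, a benzyloxy group or a simple amine would fare at this carbon. Nothing available explains the order of these groups.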